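Working notes: the step from compound 3 to compound 4

The source may hold more compounds than are shown below. What is called first, only, known or untested is meant among the compounds shown, and "the series" means these compounds.

In a functional assay on A549 cells (Homo sapiens) for antiproliferative activity, read by MTT assay, with a stated time of 72 h (a higher number here means a weaker inhibitor, a lower number a stronger inhibitor), compound 1 `O=C(N/N=C/c1ccccc1)Nc1ccc(Oc2ccnc3[nH]ccc23)c(F)c1` gives 2500 nM, compound 2 `O=C(N/N=C/c1ccc(Br)cc1)Nc1ccc(Oc2ccnc3[nH]ccc23)c(F)c1` gives 820 nM and compound 3 `O=C(N/N=C/c1ccc(F)cc1Cl)Nc1ccc(Oc2ccnc3[nH]ccc23)c(F)c1` gives 10 nM. Compound 3 has the lowest number of the three, and its steps to both others lie beyond the scatter.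

Compound 4 `O=C(N/N=C/c1ccc(O)cc1)Nc1ccc(Oc2ccnc3[nH]ccc23)c(F)c1` has not yet been measured. Its difference is 4-hydroxyphenyl in place of 2-chloro-4-fluorophenyl on a carbon with a double bond to nitrogen.

Two large steps bear on this change, a 250-fold lower number from compound 1 to compound 3 (2.40 log units; beyond the scatter) and an 82-fold lower number from compound 2 to compound 3 (1.91 log units; beyond the scatter). Both end at the 2-chloro-4-fluorophenyl group, which compound 4 gives up. Going by the values given here, the step that introduces the 4-bromophenyl group, a 3.0-fold lower number from compound 1 to compound 2 (0.48 log units; beyond the scatter), is only modest, and no measured compound carries 4-hydroxyphenyl. A large step towards a higher number is therefore expected in this assay, returning to the range of the first two compounds. The expected change is a 120-fold higher number from compound 3 to compound 4 (2.08 log units; beyond the scatter). For compound 4 the estimate is 1200 nM, with an expected range of 250 nM to 6000 nM.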

Compound 4, half-maximal inhibitory concentration: 3760 nM
The estimate for compound 4 lay 3.1-fold (0.50 log units) below the measured number; low and high end bracket the measured number.
By their numbers in this assay, from the lowest: compound 3; then compound 2; then compounds 1 and 4 (each within the scatter of the next).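

In this assay, 4-hydroxyphenyl in place of 2-chloro-4-fluorophenyl on the carbon with a double bond to nitrogen gives a 380-fold higher number from compound 3 to compound 4 (2.58 log units; beyond the scatter), so the advantage of compound 3 does not carry over to this group. Adding the hydroxy to the plain phenyl group gives a 1.5-fold higher number from compound 1 to compound 4 (0.18 log units; within the scatter), which leaves compound 4 unseparated from compound 1, while hydroxy in place of bromo gives a 4.6-fold higher number from compound 2 to compound 4 (0.66 log units; beyond the scatter), a modest step that keeps the 4-bromophenyl compound apart from the 4-hydroxyphenyl compound. Nothing measured here accounts for these steps.

The compounds shown do not separate what the chloro and the fluoro each contribute within 2-chloro-4-fluorophenyl. As far as these compounds go, how a methoxy or an amine would compare with the hydroxy on the same aromatic carbon also stays open.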